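The source may report more compounds than this note shows. Statements on the series, on what has been measured and on what is new or still open speak of the compounds shown alone.

Measured compounds:
compound 1, `CN(C(=O)c1ccc(Br)cc1)c1ccc2[nH]c(-c3n[nH]c4ccccc34)cc2n1`: 4250 nM
compound 2, `CN(C(=O)c1ccc([N+](=O)[O-])cc1)c1ccc2[nH]c(-c3n[nH]c4ccccc34)cc2n1`: 34500 nM

In a functional assay on A549 cells (Homo sapiens) for antiproliferative activity, read by MTT assay, with a stated time of 72 h (a lower number here means a stronger inhibitor, a higher number a weaker inhibitor), compound 2 gives the highest of the two numbers; compound 1 is its nearest neighbour, separated by the step of an 8.1-fold higher number from compound 1 to compound 2 (0.91 log units; beyond the scatter). Compound 3, `CN(C(=O)c1ccco1)c1ccc2[nH]c(-c3n[nH]c4ccccc34)cc2n1`, differs from compound 2 by furan-2-yl in place of 4-nitrophenyl on a carbonyl carbon. Among the measured compounds shown here, no measured step covers a furan-2-yl here; the only step available, an 8.1-fold higher number from compound 1 to compound 2 (0.91 log units; beyond the scatter), shows that exchanging the group on the carbonyl carbon can move this assay by a modest but real amount. Since compound 2 gives 34500 nM while compound 1, lacking the nitro, gives 4250 nM, a group other than 4-nitrophenyl is expected to bring the number back toward that of compound 1, though the size of the return is uncertain. Compound 3 is therefore estimated at 8000 nM, with a range from 2000 nM to 40000 nM, a step of a 4.3-fold lower number from compound 2 to compound 3 (0.63 log units; beyond the scatter).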

Compound 3, half-maximal inhibitory concentration: 15500 nM
Beside the measured number, compound 3's estimate is 1.9-fold (0.29 log units) below it; the range from low to high includes it.
By their numbers in this assay, from the lowest: compound 1; then compound 3; then compound 2.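

In this assay the group on the carbonyl carbon has now been varied beyond a substituted phenyl, and the furan-2-yl falls between the two phenyl groups, with a 2.2-fold lower number from compound 2 to compound 3 (0.35 log units; beyond the scatter) and a 3.6-fold higher number from compound 1 to compound 3 (0.56 log units; beyond the scatter) as the two printed steps. Giving up the six-membered aromatic ring of carbon for the smaller five-membered ring therefore recovers part of the difference from the 4-nitrophenyl but does not reach the number given by the 4-bromophenyl. Among these three compounds, the position tolerates a change of ring as well as a change of substituent on the ring, with all steps remaining modest. Nothing available explains this order.

From the compounds shown here alone, what an unsubstituted phenyl or a thiophene would give on this carbonyl carbon remains open. So does the effect of a phenyl carrying an amine or a carboxylic acid.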